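The source may hold more compounds than are shown below. What is called first, only, known or untested is meant among the compounds shown, and "the series" means these compounds.

In an ADME assay on microsomes from liver (Rattus norvegicus) for metabolic stability (a higher number here means that the compound lasts longer, a lower number that the compound disappears faster), compound 1 `N#Cc1ccc(-c2nc(NCCNc3ccc([N+](=O)[O-])c(N)n3)ncc2-c2ncc[nH]2)cc1` gives > 0.5 h, which is a limit of the assay and not a number. Compound 2 `Nc1nc(NCCNc2ncc(-c3ncc[nH]3)c(-c3cc(F)ccc3Cl)n2)ccc1[N+](=O)[O-]` gives > 0.5 h, again a limit and not a number. Compound 2 therefore stands at the limit of > 0.5 h in this assay, at which 2 of the 2 values shown sit, with no exact half-life to start from.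

Compound 3 `Nc1nc(NCCNc2ncc(-c3ncc[nH]3)c(-c3ccc(F)cc3Cl)n2)ccc1[N+](=O)[O-]` keeps the shared core. In it, 2-chloro-4-fluorophenyl takes the place of 2-chloro-5-fluorophenyl on an aromatic carbon, ortho to a 1H-imidazol-2-yl group, and the two compounds have the same atoms, joined differently (2-chloro-4-fluorophenyl in place of 2-chloro-5-fluorophenyl on an aromatic carbon).

Going by the values given here, the only measured step at this place is a step that the two limits leave unreadable from compound 1 to compound 2, so it offers no size to carry over. With so small a structural change and no readable step as a guide, no shift beyond the usual scatter is expected in this assay, and no direction can be favoured. The expected step is a step that the limit leaves unreadable from compound 2 to compound 3. For compound 3 the estimated half-life is 0.7 h, with an expected range from 0.35 h to 1.5 h.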

Compound 3, half-life: > 0.5 h
Compound 3: no number, only a limit; the forecaster's own chance of this, stated with the estimate: 65%; the middle value lies beyond the limit too.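

Compound 3 gives a limit and not a number in this assay, as do compound 1 and compound 2, so no step among these three compounds can be read: the limit of > 0.5 h in this assay, at which 3 of the 3 values shown sit.

The compounds shown leave open the actual half-life of each compound, and whether 4-cyanophenyl, 2-chloro-5-fluorophenyl and 2-chloro-4-fluorophenyl differ at all in this respect.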